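The source may hold more compounds than are shown below. What is called first, only, known or untested is meant among the compounds shown, and "the series" means these compounds.

In an ADME assay on L6 cells (Rattus norvegicus) for cytotoxicity (a higher number here means a weaker inhibitor, a lower number a stronger inhibitor), compound 1 (`CN(C)C12CC(OC(=O)CN3CCCC3)C(C(c3ccccc3)C1)C(c1ccccc1)C2`) gives 32700 nM. Among the compounds with values here, the only other number available comes from compound 2 (`O=C(CN1CCCC1)OC1CC2(N3CCCC3)CC(c3ccccc3)C1C(c1ccccc1)C2`), which gives 42900 nM, and the two lie within the scatter of each other. Compound 3 (`CCN(CC)CCC(=O)OC1CC2(N(C)C)CC(c3ccccc3)C1C(c1ccccc1)C2`) keeps the dimethylamino group of compound 1 on the saturated ring carbon and differs at another place: (diethylamino)methyl in place of pyrrolidin-1-yl on a saturated chain carbon bound to a carbonyl carbon. There, (diethylamino)methyl stands in place of pyrrolidin-1-yl on a saturated chain carbon bound to a carbonyl carbon. Cut one bond further out, (pyrrolidin-1-yl)methyl becomes 2-(diethylamino)ethyl. Within the data shown here, no measured step tests this exchange directly. The only one available, a 1.3-fold higher number from compound 1 to compound 2 (0.12 log units; within the scatter), puts pyrrolidin-1-yl in place of dimethylamino on a saturated ring carbon, so it bears on the new change only loosely. Since that step to compound 2 stays within the scatter, and nothing else points either way, no shift beyond the scatter is expected in this assay. The expected step is a 1.1-fold lower number from compound 1 to compound 3 (0.04 log units; within the scatter). For compound 3 the estimated value is 30000 nM, with an expected range from 14000 nM to 65000 nM.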

Compound 3, half-maximal inhibitory concentration: 23600 nM
For compound 3 the middle estimate is 1.3-fold (0.10 log units) above the measured one, within the range that was stated.
By their numbers in this assay, from the lowest: compounds 3, 1 and 2 (each within the scatter of the next).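

Within the data shown here, compound 1 and compound 2 share pyrrolidin-1-yl on the saturated chain carbon bound to a carbonyl carbon, so they could say nothing about this position; in this assay the first reading of it is a 1.4-fold lower number from compound 1 to compound 3 (0.14 log units; within the scatter) and lies within the scatter. With dimethylamino kept on the saturated ring carbon, the pyrrolidin-1-yl ring can therefore give way to (diethylamino)methyl, which has no ring, without a shift beyond the scatter in this read-out. Nothing available here explains why the numbers stay within the scatter of each other.

As far as these compounds go, it remains open whether the same exchange would read alike with pyrrolidin-1-yl rather than dimethylamino on the saturated ring carbon, a question that compound 2 alone cannot settle. Also open, from the compounds shown here alone, is whether a piperidine, a morpholine, a primary amine or a still longer chain at this position would move the number beyond the scatter, or whether the position tolerates such changes as it tolerates this one.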